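Two Long-Chain Amines Level, an Acylated Acid Untested

A few compounds are considered here, and "the series" means these few. Any claim that something is new, unique, unknown or untested is made for them only; others in the source may bear on it.

Compound 1 `CCCCCCCCCCCCCCC(COCc1ccccc1)NCC`: 6000 nM
Compound 2 `CCCCCCCCCCCCCCC(CO)NCCCCCC`: 6000 nM

In a functional assay on Jurkat cells (Homo sapiens) for inhibition (on this read-out lower numbers stand for stronger inhibition and higher numbers for weaker inhibition), compound 1 gives 6000 nM, level with compound 2, which gives 6000 nM, a difference within the scatter. Compound 3 `CCCCCCCCCCCCCCC(COCc1ccccc1)NC(=O)CCCC(=O)O` differs from compound 1 by (3-carboxypropyl)carbonyl in place of ethyl on an amine nitrogen. No step of this kind has been measured among these compounds, so the direction rests on expectation alone. The step of a 2.5-fold higher number from compound 1 to compound 3 (0.40 log units; beyond the scatter) is expected to bring weaker inhibition, beyond the scatter. Compound 3 is therefore estimated at 15000 nM, with a range from 4000 nM to 60000 nM.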

Compound 3, half-maximal inhibitory concentration: > 50000 nM
Compound 3 ended at the assay's limit; the forecaster's own chance of this, stated with the estimate: 30%; middle value at least 3.3-fold (0.52 log units) from the limit.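

In this assay, (3-carboxypropyl)carbonyl in place of ethyl on an amine nitrogen gives an at least 8.3-fold higher number from compound 1 to compound 3 (0.92 log units; beyond the scatter), so this nitrogen does not tolerate every substituent and this change weakens inhibition. For compound 3 the value > 50000 nM is a limit of the assay and not a number, so the full size of the step cannot be read: the limit of > 50000 nM in this assay, at which 1 of the 3 values shown sits.

The compounds shown do not separate the carbonyl on the nitrogen from the carboxylic acid as the source of the weaker inhibition. An acetyl group on that nitrogen, or a methyl ester in place of the carboxylic acid, would tell the two apart.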